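Trimming the ether side chain: compound 2 to compound 3

A few compounds are considered here, and "the series" means these few. Any claim that something is new, unique, unknown or untested is made for them only; others in the source may bear on it.

Among the measured compounds shown here, in a functional assay on PC-3 cells (Homo sapiens) for antiproliferative activity, read by sulforhodamine B assay (on this read-out lower numbers stand for stronger inhibition of growth and higher numbers for weaker inhibition of growth), compound 2 `CCC(CC)COc1cccc(O)c1C(=O)/C=C/c1ccc(O)cc1` gives 3390 nM, the only true number available so far. Compound 1 `CC(C)=CCOc1cccc(O)c1C(=O)/C=C/c1ccc(O)cc1` is reported only as a limit, > 30000 nM. Compound 2 therefore has no measured neighbour to be ranked against, only that limit.

Compound 3 `CC(C)COc1cccc(O)c1C(=O)/C=C/c1ccc(O)cc1` is the next case: isopropyl in place of pentan-3-yl on a saturated chain carbon bound to an oxygen on an aromatic ring. Here isopropyl stands in place of pentan-3-yl on a saturated chain carbon bound to an oxygen on an aromatic ring, and the shared core is unchanged.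

For the measured compounds named here, one measured step bears on this, an at least 8.8-fold lower number from compound 1 to compound 2 (0.94 log units; beyond the scatter). That step replaces a different group at the same place, and its size is a bound, not an exact figure. It shows only that this assay can respond strongly to a change at this chain end. With so little evidence, a move toward weaker inhibition of growth is expected, smaller than the step to compound 2 from compound 1. The expected step is a 2.7-fold higher number from compound 2 to compound 3 (0.42 log units; beyond the scatter). For compound 3 the estimated value is 9000 nM, with an expected range of 3000 nM to 28000 nM.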

Compound 3, concentration for 50% growth inhibition: 2970 nM
The estimate for compound 3 lay 3.0-fold (0.48 log units) above the measured number, and the stated range ends above it.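

In this assay, isopropyl in place of pentan-3-yl on a saturated chain carbon bound to an oxygen on an aromatic ring gives a 1.1-fold lower number from compound 2 to compound 3 (0.06 log units; within the scatter), so removing the two extra carbons of pentan-3-yl leaves the read-out unmoved, which a single pair could not show before. The chain end with the 2-methylprop-1-en-1-yl group now stands apart from two saturated branched ends rather than one, with an at least 10-fold lower number from compound 1 to compound 3 (1.00 log units; beyond the scatter) pointing the same way as an at least 8.8-fold lower number from compound 1 to compound 2 (0.94 log units; beyond the scatter). Compound 1 is held only at a limit, so both of these steps are bounds and not exact sizes: the limit of > 30000 nM in this assay, at which 1 of the 3 values shown sits.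

The three compounds do not settle whether the gap to compound 1 belongs to the carbon-carbon double bond itself, since its chain end also differs from the others in shape, and a saturated 3-methylbutyl end would be the closest test of that. From the compounds shown here alone, how far the flat response extends also stays open, for instance to a longer straight chain, a cyclohexyl group, or an amine or carboxylic acid at the chain end.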